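From fluoro to hydroxy on a shared core

The source may report more compounds than this note shows. Statements on the series, on what has been measured and on what is new or still open speak of the compounds shown alone.

Two compounds have been measured so far in a functional assay on HT-29 cells (Homo sapiens) for inhibition, with a stated time of 72 h; on this read-out higher numbers stand for weaker inhibition and lower numbers for stronger inhibition:

- compound 1 `COc1ccc(S(=O)(=O)N2CCc3cccc(-c4cc(OC)c(OC)c(OC)c4)c32)cc1` gives 5100 nM
- compound 2 `COc1ccc(S(=O)(=O)N2CCc3cccc(-c4ccc(F)cc4)c32)cc1` gives 85.5 nM

Compound 2 holds the lower of the two numbers, which makes it the stronger inhibitor here, and its gap to compound 1 lies beyond the usual scatter. The next molecule, compound 3 `COc1ccc(S(=O)(=O)N2CCc3cccc(-c4ccc(O)cc4)c32)cc1`, keeps the shared core and differs from compound 2 in one place (hydroxy in place of fluoro on an aromatic carbon), with hydroxy in place of fluoro on an aromatic carbon, para to a large group. For the measured compounds named here, no measured pair shows this exchange on its own, so the expectation is a cautious one. The expected change is a 2.3-fold higher number from compound 2 to compound 3 (0.37 log units; beyond the scatter), a moderate rise in the number that would mean somewhat weaker inhibition. For compound 3 the estimate is 200 nM, with a range of 40 nM to 1000 nM expected.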

Compound 3, half-maximal inhibitory concentration: 133 nM
Estimate against measurement, compound 3: 1.5-fold (0.18 log units) above; the measured number falls inside the stated range.
By their numbers in this assay, from the lowest: compounds 2 and 3 (each within the scatter of the next); then compound 1.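

In this assay the exchange of fluoro for hydroxy on an aromatic carbon, para to a large group, gives a 1.6-fold higher number from compound 2 to compound 3 (0.19 log units; within the scatter) and so does not separate the two groups on this read-out. This is the first pair shown that differs in one place only, and it reveals that 4-fluorophenyl and 4-hydroxyphenyl cannot be told apart here, even though hydroxy adds a hydrogen-bond donor and a hydrogen-bond acceptor. No measurement is available that would explain this result.

Still open, going by these compounds, is whether an amine or a carboxylic acid in this same place would also stay within the scatter of compound 2. Also open is which of the three methoxy groups, if any single one, accounts for compound 1 giving 5100 nM in this read-out, as no one-place step reaches that compound.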